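Notes on compound 3 and its bis(3-hydroxypropyl)amino group

A few compounds are considered here, and "the series" means these few. Any claim that something is new, unique, unknown or untested is made for them only; others in the source may bear on it.

In an ADME assay on A549 cells (Homo sapiens) for cytotoxicity, read by resazurin assay, with a stated time of 48 h (a lower number here means that less compound is tolerated, a higher number that more compound is tolerated), compound 1 (`O=C(Nc1ccc(NCc2ccc(F)cc2)cc1Cl)c1cc(Cl)ccc1O`) gives 54400 nM and compound 2 (`O=C(Nc1ccc(NCc2ccc(Br)s2)cc1Cl)c1cc(Cl)ccc1O`) gives 20700 nM as the lower of the two numbers. Compound 3 (`O=C(Nc1ccc(N(CCCO)CCCO)cc1Cl)c1cc(Cl)ccc1O`) carries bis(3-hydroxypropyl)amino in place of ((5-bromothiophen-2-yl)methyl)amino on an aromatic carbon. For the measured compounds named here, the one measured step at this place (a 2.6-fold lower number from compound 1 to compound 2 (0.42 log units; beyond the scatter)) replaces one ring with another, so it is only a weak guide to a group with no ring. A modest rise of similar size is expected (a 2.2-fold higher number from compound 2 to compound 3 (0.34 log units; beyond the scatter)) given that compound 2 sits lowest. For compound 3 the estimated value is 45000 nM with an expected range (17000 nM to 110000 nM).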

Compound 3, half-maximal cytotoxic concentration: 114000 nM
For compound 3 the middle estimate is 2.5-fold (0.40 log units) below the measured one, and the stated range ends below it.
By their numbers in this assay, from the lowest: compound 2; then compound 1; then compound 3.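

In this assay, the change to bis(3-hydroxypropyl)amino gives a 5.5-fold higher number from compound 2 to compound 3 (0.74 log units; beyond the scatter) and a 2.1-fold higher number from compound 1 to compound 3 (0.32 log units; beyond the scatter), so a group with no ring at this position carries the highest number of the three. For the compounds shown here, both ring-bearing groups now sit below a ring-free one, whereas the earlier pair compared only one ring with another. Nothing available explains either step.

The compounds shown do not separate the contribution of the two hydroxyl groups from that of losing the ring. A dipropylamino group at this position would bear on that question.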